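Isopropyl for cyclopropyl on the sulfonamide of compound 1

The source may report more compounds than this note shows. Statements on the series, on what has been measured and on what is new or still open speak of the compounds shown alone.

Measured compounds:
compound 1 `O=S(=O)(Nc1cccc2c1CCCC2c1c[nH]cn1)C1CC1` — < 10000 nM
compound 2 `CS(=O)(=O)Nc1ccc(F)c2c1CCCC2c1c[nH]cn1` — < 10000 nM

In an assay on isolated protein (Cricetulus griseus) for binding affinity to Alpha-1B adrenergic receptor (Mesocricetus auratus), read by radioligand binding (on this read-out lower numbers stand for stronger inhibition and higher numbers for weaker inhibition), compound 1 gives only a limit, < 10000 nM. Compound 2 likewise gives only a limit in this assay, < 10000 nM. Both values sit at the limit of < 10000 nM in this assay, at which 2 of the 2 values shown sit, so compound 1 has no exact number to stand on. Compound 3 `CC(C)S(=O)(=O)Nc1cccc2c1CCCC2c1c[nH]cn1` differs from compound 1 by isopropyl in place of cyclopropyl on a sulfonyl sulfur. Among the compounds with values here, with no measured step to guide it, the change is expected to move this assay by no more than the usual scatter, a step that the limit leaves unreadable from compound 1 to compound 3. Compound 3 is therefore estimated at 1000 nM, with a range from 100 nM to 10000 nM.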

Compound 3, inhibition constant: < 10000 nM
Compound 3 gave a limit, no number (the forecaster's own chance of this, stated with the estimate: 70%); the middle value does not contradict the limit.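

No step can be read from compound 1 to compound 3 in this assay because both give only limits: the limit of < 10000 nM in this assay, at which 3 of the 3 values shown sit. The compounds shown leave open whether isopropyl and cyclopropyl on a sulfonyl sulfur differ at all in this read-out.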